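Sulfonyl substitution in a trifluoromethylphenyl pyrazole series

This account rests on a few compounds, and the source may have more. Where it says the series, first, only, none or still open, it means among the compounds named here.

Measured compounds in a functional assay on HeLa cells (Homo sapiens) for antiproliferative activity, read by MTT assay, with a stated time of 24 h; a higher number here means a weaker inhibitor, a lower number a stronger inhibitor:
- compound 1, `FC(F)(F)c1ccc(-c2nn(-c3ccccc3)cc2-c2nc3ccccc3[nH]2)cc1`, 4670 nM
- compound 2, `O=S(=O)(c1ccccc1)n1c(-c2cn(-c3ccccc3)nc2-c2ccc(C(F)(F)F)cc2)nc2ccccc21`, 560 nM

Among the compounds with values here, compound 2 has the lowest number of the two measured in this assay; its nearest neighbour is compound 1, and the only measured step, an 8.3-fold lower number from compound 1 to compound 2 (0.92 log units; beyond the scatter), separates them.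

Compound 3, `O=[N+]([O-])c1ccc(S(=O)(=O)n2c(-c3cn(-c4ccccc4)nc3-c3ccc(C(F)(F)F)cc3)nc3ccccc32)cc1`, is not yet measured. It differs from compound 2 as follows: nitro in place of hydrogen on an aromatic carbon. Within the data shown here, no measured step touches this position; the single step known, from compound 1 to compound 2, concerns the phenylsulfonyl itself and says nothing about a substituent on its ring. Without a comparable step, no change beyond the scatter is expected in this assay in either direction. The estimate for compound 3 is therefore close to compound 2, 500 nM, with a range of 150 nM to 1600 nM, which corresponds to an expected step of a 1.1-fold lower number from compound 2 to compound 3 (0.05 log units; within the scatter).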

Compound 3, half-maximal inhibitory concentration: 950 nM
The estimate for compound 3 lay 1.9-fold (0.28 log units) below the measured number; measured number inside the range.
By their numbers in this assay, from the lowest: compounds 2 and 3 (each within the scatter of the next); then compound 1.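

In this assay, the ring of the phenylsulfonyl group accepts a nitro group, giving (4-nitrophenyl)sulfonyl, without a change beyond the scatter (a 1.7-fold higher number from compound 2 to compound 3 (0.23 log units; within the scatter)). The advantage over hydrogen on the aromatic nitrogen remains with this larger group (a 4.9-fold lower number from compound 1 to compound 3 (0.69 log units; beyond the scatter)), so within these compounds it is not confined to the plain phenylsulfonyl group. No supporting measurement is available to explain either step.

From the compounds shown here alone, with only hydrogen and nitro compared on this ring, it remains open how an amine, a carboxylic acid or a methoxy group at the same place would read in this assay. Also open, going by these compounds, are nitro on another carbon of the ring and whether an acetyl group on the aromatic nitrogen could stand in for the sulfonyl groups.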